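Swapping One Ring Group on a Shared Core

The source may hold more compounds than are shown below. What is called first, only, known or untested is meant among the compounds shown, and "the series" means these compounds.

Of the compounds shown here, two with the same core have been measured in an ADME assay on microsomes from liver (Homo sapiens) for metabolic stability, with a stated time of 30 min, tested at 1 uM; a lower number here means that the compound disappears faster, a higher number that the compound lasts longer. Compound 1 (`COc1ccc2[nH]c(C(=O)N3CC(=O)N(Cc4ccccc4)[C@@H](CN4CCC5(CC4)CC5)C3)cc2c1`) gives 0.867 h, and compound 2 (`COc1ccc2[nH]c(C(=O)N3CC(=O)N(Cc4ccccc4)[C@@H](CN4CCN(c5ccc(F)cc5)CC4)C3)cc2c1`) gives 0.457 h. On these numbers compound 1 cannot be separated from compound 2, as the two values lie within the usual scatter of each other.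

Compound 3 (`COc1ccc2[nH]c(C(=O)N3CC(=O)N(Cc4ccccc4)[C@@H](CN4CC5CC5C4)C3)cc2c1`) has not yet been measured. It departs from compound 1 in a single place, on a saturated chain carbon bound to a saturated ring carbon: a group of 6 heavy atoms (5 carbon, 1 nitrogen; one three-membered non-aromatic ring of carbon only, one five-membered non-aromatic ring with 1 hetero atom) in place of a group of 8 heavy atoms (7 carbon, 1 nitrogen; one three-membered non-aromatic ring of carbon only, one six-membered non-aromatic ring with 1 hetero atom), on a saturated chain carbon bound to a saturated ring carbon. The six-membered non-aromatic ring gives way to a five-membered non-aromatic ring, and a three-membered non-aromatic ring of carbon only remains.

Going by the values given here, no measured pair differs in one place alone, so direct evidence for this step is lacking. Compound 2, at 0.457 h, carries another group at that place and still lies within the scatter of compound 1, so no step beyond the scatter is expected in this assay, and neither direction is favoured. The expected step, a 1.0-fold lower number from compound 1 to compound 3 (0.01 log units; within the scatter), is estimated to stay within the scatter. For compound 3 the half-life is estimated at 0.85 h, with an expected range from 0.43 h to 1.7 h.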

Compound 3, half-life: 0.35 h
The estimate for compound 3 lay 2.4-fold (0.39 log units) above the measured number; measured number below the stated range.
By their numbers in this assay, from the lowest: compounds 3, 2 and 1 (each within the scatter of the next, the first and the last beyond it).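

In this assay, the place on a saturated chain carbon bound to a saturated ring carbon now has its first measured single change, a 2.5-fold lower number from compound 1 to compound 3 (0.39 log units; beyond the scatter), a modest step that lies beyond the scatter. The result shows that the half-life can respond to the group at this place even though the three-membered non-aromatic ring of carbon only remains, the six-membered non-aromatic ring gives way to a five-membered one, and the two groups carry the same counts of hydrogen-bond donors and acceptors and no net charge. No measurement shown here bears on the reason for this step.

Ring size and group size change together in this one pair, a group of 6 heavy atoms replacing a group of 8 heavy atoms, and the compounds shown leave open which of the two goes with the lower half-life. Going by these compounds, it also remains open how the half-life would respond to a plain piperidine or pyrrolidine at this place, neither of which carries the three-membered ring, or to a morpholine, whose ring holds an oxygen.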